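Replacing a Pivalate Ester with a Dimethylaminomethyl Group

A few compounds are considered here, and "the series" means these few. Any claim that something is new, unique, unknown or untested is made for them only; others in the source may bear on it.

Measured compounds:
compound 1 `Cc1ccc(Nc2nc(C(F)(F)F)ccc2CNC(=O)C(C)c2ccc(NS(C)(=O)=O)c(F)c2)cc1C`, 39.3 nM
compound 2 `CC(C(=O)NCc1ccc(C(F)(F)F)nc1N1CC=CCC1)c1ccc(NS(C)(=O)=O)c(F)c1`, 0.3 nM
compound 3 `CC(C(=O)NCc1ccc(C(F)(F)F)nc1N1CCC(OC(=O)C(C)(C)C)CC1)c1ccc(NS(C)(=O)=O)c(F)c1`, 2 nM

All three share a core, and they were tested in a functional assay on CHO-K1 cells for antagonist activity at transient receptor potential cation channel subfamily V member 1 (Homo sapiens), read by FLIPR; on this read-out higher numbers stand for weaker inhibition and lower numbers for stronger inhibition. Compound 3 stands second highest of the three numbers; compound 2 gives 0.3 nM, and compound 1 gives 39.3 nM.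

The new compound is compound 4 `CC(C(=O)NCc1ccc(C(F)(F)F)nc1N1CCC(CN(C)C)CC1)c1ccc(NS(C)(=O)=O)c(F)c1`. It differs from compound 3 in one place: (dimethylamino)methyl in place of ((tert-butyl)carbonyl)oxy on a saturated ring carbon.

Going by the values given here, only one step between measured compounds is known, a 130-fold lower number from compound 1 to compound 2 (2.12 log units; beyond the scatter), and it concerns a swap of the whole ring attached to the core, not a change on a saturated carbon of that ring. Among the compounds with values here, no measured step bears directly on the change from compound 3 to compound 4. What the values of compound 2 and compound 3 show is that this six-membered ring, bare or carrying a large group, keeps a low number in this assay. With no closer guide, the expected step is no change at the digits printed from compound 3 to compound 4 (within the scatter), a modest change in either direction. Compound 4 is therefore estimated at 2 nM, with a range from 0.5 nM to 8 nM.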

Compound 4, inhibition constant: 2.1 nM
Estimate against measurement, compound 4: 1.1-fold (0.02 log units) below, and the stated range covers the measured number.
By their numbers in this assay, from the lowest: compound 2; then compounds 3 and 4 (each within the scatter of the next); then compound 1.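

On this saturated ring carbon, (dimethylamino)methyl and ((tert-butyl)carbonyl)oxy cannot be told apart in this assay (a 1.1-fold higher number from compound 3 to compound 4 (0.02 log units; within the scatter)), so an ester is not needed here to keep the number low, and a group with an amine nitrogen serves as well. Changing the whole group on the aromatic carbon matters more: the ring of compound 2 still gives the lower number (a 7.0-fold higher number from compound 2 to compound 4 (0.85 log units; beyond the scatter)), while 4-((dimethylamino)methyl)piperidin-1-yl in place of (3,4-dimethylphenyl)amino gives a clear gain (a 19-fold lower number from compound 1 to compound 4 (1.27 log units; beyond the scatter)). No supporting data explain why the ester and the amine read alike.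

On these data alone, whether a carboxylic acid, a primary amine or a longer chain on this carbon would read the same remains open. A plain methyl group there would show whether the dimethylamino nitrogen contributes at all.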